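Halogen swap on the shared core: notes toward compound 4

The source may hold more compounds than are shown below. What is called first, only, known or untested is meant among the compounds shown, and "the series" means these compounds.

Of the compounds shown here, three have been measured in a functional assay on T98G cells (Homo sapiens) for inhibition, read by MTT assay, with a stated time of 72 h; a lower number here means a stronger inhibitor, a higher number a weaker inhibitor. Compound 1 `CC1(C)CC(NC(=O)Nc2ccccc2Cl)c2cc(F)ccc2O1` gives 27000 nM, compound 2 `CC1(C)CC(NC(=O)Nc2ccccc2Cl)c2cc(Cl)ccc2O1` gives 20000 nM, and compound 3 `CC1(C)CC(NC(=S)Nc2ccc([N+](=O)[O-])cc2)c2cc(Cl)ccc2O1` gives 4000 nM. Within the data shown here, compound 3 stands lowest of the three, and both of its gaps to the others lie beyond the scatter, so it is the most potent compound measured so far.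

Compounds 1 and 2 share a core and differ in one place: fluoro in place of chloro on an aromatic carbon. This change gave a 1.4-fold higher number from compound 2 to compound 1 (0.13 log units; within the scatter), a step within the scatter. The difference between the core of compound 2 and the core of compound 3 is not broken down here.

Compound 4 `CC1(C)CC(NC(=S)Nc2ccc([N+](=O)[O-])cc2)c2cc(F)ccc2O1` has not been measured. It differs from compound 3 by fluoro in place of chloro on an aromatic carbon. The place is described in the same words as for the pair of compound 2 and compound 1, so this is the same change made on the other core. Among the measured compounds shown here, the only precedent is the single step from compound 2 to compound 1, which stayed within the scatter, and nothing shows how the change behaves on the core of compound 3.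

On that basis the step from compound 3 to compound 4 in this assay is expected to be about a 1.3-fold higher number from compound 3 to compound 4 (0.10 log units; within the scatter), resting on the small step seen from compound 2 to compound 1 with a 1.4-fold higher number from compound 2 to compound 1 (0.13 log units; within the scatter). Compound 4 is accordingly estimated at 5000 nM, with a range from 2000 nM to 13000 nM.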

Compound 4, half-maximal inhibitory concentration: 5000 nM
Beside the measured number, compound 4's estimate shows no gap at the digits printed, within the range that was stated.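

In this assay, fluoro in place of chloro on an aromatic carbon gives a 1.3-fold higher number from compound 3 to compound 4 (0.10 log units; within the scatter), and this step can be set directly against the one seen on the other core: the same change on two cores in this assay, a 1.4-fold higher number (0.13 log units; within the scatter) from compound 2 to compound 1 and a 1.3-fold higher number (0.10 log units; within the scatter) from compound 3 to compound 4, 1.1-fold (0.03 log units) apart, within the scatter of two such steps

The swap therefore carries from the core of compound 2 to the core of compound 3 without a difference that can be resolved, and on neither core can fluoro and chloro at this place be told apart in this assay. Among these compounds, this rests on only two pairs on two cores, so it shows neither that the swap would stay this small on further cores nor any order between the two halogens.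

Still open, going by these compounds, is whether a group of another kind at this place, such as methoxy, a nitrile or an amine, would give a step beyond the scatter, since the two halogens cover only a narrow part of what could sit there. Also open, on these data alone, is how compound 3 and compound 4 would respond to a change elsewhere, for example a carboxylic acid or an amine in place of the nitro group, or a carbonyl in place of the thiocarbonyl with all else held fixed.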